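A few compounds are considered here, and "the series" means these few. Any claim that something is new, unique, unknown or untested is made for them only; others in the source may bear on it.

Measured so far in a functional assay on A549 cells (Homo sapiens) for cytotoxicity, read by MTT assay, with a stated time of 48 h; on this read-out higher numbers stand for weaker inhibition and lower numbers for stronger inhibition:
- compound 1 `Cc1ccc(S(=O)(=O)/N=C(/CCNC2=CC(=O)c3ccccc3C2=O)Nc2cccc(C(F)(F)F)c2)cc1`: 78500 nM
- compound 2 `COc1cc(N/C(CCNC2=CC(=O)c3ccccc3C2=O)=N\S(=O)(=O)c2ccc(C)cc2)cc(OC)c1OC`: 7940 nM

Within the data shown here, compound 2 stands at the lowest of the two numbers in this assay; compound 1 is the nearest, and the one counted step, a 9.9-fold lower number from compound 1 to compound 2 (1.00 log units; beyond the scatter), separates them.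

Compound 3 `Cc1ccc(S(=O)(=O)/N=C(/CCNC2=CC(=O)c3ccccc3C2=O)NC(C)C)cc1` is not yet measured. It differs from compound 2 in one place: isopropyl in place of 3,4,5-trimethoxyphenyl on an amine nitrogen. Among the measured compounds shown here, the only measured step, a 9.9-fold lower number from compound 1 to compound 2 (1.00 log units; beyond the scatter), concerns the exchange of one aryl group for another on the same amine nitrogen, not the loss of the aromatic ring altogether, so it bears on the present change only loosely: it shows that this position is sensitive to substitution, and that the trimethoxyphenyl group of compound 2 goes with the lower number. Removing that group in favour of a small alkyl is therefore expected to move the number upward in this assay, by a step of the order seen between compound 1 and compound 2, but the direction is inferred from a single step and the uncertainty is wide.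

The estimated step is a 5.0-fold higher number from compound 2 to compound 3 (0.70 log units; beyond the scatter). For compound 3 the expected value in this assay is 40000 nM, with a range from 10000 nM to 150000 nM.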

Compound 3, half-maximal inhibitory concentration: 44300 nM
Beside the measured number, compound 3's estimate is 1.1-fold (0.04 log units) below it, within the range that was stated.
By their numbers in this assay, from the lowest: compound 2; then compounds 3 and 1 (each within the scatter of the next).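

In this assay the exchange of 3,4,5-trimethoxyphenyl for isopropyl on this amine nitrogen gives a 5.6-fold higher number from compound 2 to compound 3 (0.75 log units; beyond the scatter) and so loses the standing of compound 2, which shows that the low number does not survive the removal of this aromatic group. The second comparison, a 1.8-fold lower number from compound 1 to compound 3 (0.25 log units; within the scatter), lies within the scatter, so isopropyl and 3-(trifluoromethyl)phenyl cannot be told apart at this position; an aromatic ring on this nitrogen therefore does not by itself go with the lower number, and compound 1 is the compound that goes against such a reading. No measurement at hand accounts for the separate standing of compound 2.

Still open, from the compounds shown here alone, is whether that standing belongs to the methoxy groups or to their arrangement on the ring, a question that a plain phenyl or a 4-methoxyphenyl on the same amine nitrogen would address. Also open, going by these compounds, is whether a cyclohexyl, a longer alkyl chain or a chain ending in an amine at this position would sit with compound 3 or with compound 2.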